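Moving the methoxy group on the aryl substituent

The compounds below may be only part of what the source reports. "The series", "measured", "known", "first", "only" and "open" are said of these compounds alone.

Values in a functional assay on NCI-H460 cells (Homo sapiens) for antiproliferative activity, read by MTT assay, with a stated time of 48 h; a higher number here means a weaker inhibitor, a lower number a stronger inhibitor:
- compound 1 `COc1cc(-c2cccc3nc(-c4ccccc4)oc23)cc(OC)c1OC`: 6800 nM
- compound 2 `COc1ccc(-c2nc3cccc(-c4cc(OC)c(OC)c(OC)c4)c3o2)cc1`: 3500 nM

Compound 2 has only compound 1 to compare with, and the two numbers sit within the scatter of each other. Compound 3 `COc1cccc(-c2nc3cccc(-c4cc(OC)c(OC)c(OC)c4)c3o2)c1` follows from compound 2 by 3-methoxyphenyl in place of 4-methoxyphenyl on an aromatic carbon. Within the data shown here, the only measured step that bears on this is a 1.9-fold lower number from compound 1 to compound 2 (0.29 log units; within the scatter), which is methoxy in place of hydrogen on an aromatic carbon. Adding the methoxy made no difference beyond the scatter, so relocating it is expected to produce no step beyond the scatter in this assay. The estimate amounts to an expected 1.1-fold higher number from compound 2 to compound 3 (0.06 log units; within the scatter). Compound 3 is estimated at 4000 nM, with an expected range of 1800 nM to 9000 nM.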

Compound 3, half-maximal inhibitory concentration: > 25000 nM
Compound 3: only a limit was reported; the forecaster's own chance of this, stated with the estimate: 3%; middle value at least 6.2-fold (0.79 log units) from the limit.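

In this assay, where the methoxy sits on the aryl ring matters, which the addition to compound 2 did not show: 3-methoxyphenyl in place of 4-methoxyphenyl gives an at least 7.1-fold higher number from compound 2 to compound 3 (0.85 log units; beyond the scatter). Measured against the unsubstituted phenyl, the same group gives an at least 3.6-fold higher number from compound 1 to compound 3 (0.56 log units; beyond the scatter), so 3-methoxyphenyl is the one substituent here that separates from the others beyond the scatter. Compound 3 carries a limit and not a number, so both steps are minimum sizes: the limit of > 25000 nM in this assay, at which 1 of the 3 values shown sits. Still open, on these data alone, is whether the loss belongs to methoxy alone. A hydroxy or an amine carried in the same place as in 3-methoxyphenyl would test this.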